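The source may report more compounds than this note shows. Statements on the series, on what has been measured and on what is new or still open speak of the compounds shown alone.

Measured so far in a functional assay on MIA PaCa-2 cells (Homo sapiens) for cytotoxicity, read by MTT assay, with a stated time of 4 h; on this read-out lower numbers stand for stronger inhibition and higher numbers for weaker inhibition:
- compound 1 `COC1=CC(=O)c2c(COc3ccccc3)c(C)n(C)c2C1=O`: 4560 nM
- compound 2 `COC1=CC(=O)c2c(COc3cccc([N+](=O)[O-])c3)c(C)n(C)c2C1=O`: 351 nM
- compound 3 `COC1=CC(=O)c2c(COc3ccccc3[N+](=O)[O-])c(C)n(C)c2C1=O`: 363 nM

Compound 1 has the highest number of the three, and its steps to the other two lie beyond the scatter. The values of compound 2 and compound 3 lie within the scatter of each other.

The next compound to be read is compound 4 `COC1=CC(=O)c2c(COc3ccc(C(F)(F)F)cc3)c(C)n(C)c2C1=O`, which differs from compound 1 as follows: trifluoromethyl in place of hydrogen on an aromatic carbon. It therefore carries trifluoromethyl in place of hydrogen on an aromatic carbon, para to a large group.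

Among the measured compounds shown here, two measured steps bear on this change, and both put nitro in place of hydrogen on an aromatic carbon. They are a 13-fold lower number from compound 1 to compound 2 (1.11 log units; beyond the scatter) and a 13-fold lower number from compound 1 to compound 3 (1.10 log units; beyond the scatter), both large. Both substitutions on this aromatic ring lowered the number by a similar amount, so a lower number is also expected for compound 4 in this assay. The evidence is indirect, however. The entering group is different, and neither nitro compound has its group at the place changed in compound 4, so a smaller step is expected than with nitro.

The estimated change is a 3.8-fold lower number from compound 1 to compound 4 (0.58 log units; beyond the scatter). For compound 4 the expected value is 1200 nM, with an estimated range from 350 nM to 4000 nM.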

Compound 4, half-maximal inhibitory concentration: 496 nM
Estimate against measurement, compound 4: 2.4-fold (0.38 log units) above; the range from low to high includes it.
By their numbers in this assay, from the lowest: compounds 2, 3 and 4 (each within the scatter of the next); then compound 1.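

In this assay the place para to a large group on the six-membered aromatic ring proves open to substitution: trifluoromethyl in place of hydrogen there gives a 9.2-fold lower number from compound 1 to compound 4 (0.96 log units; beyond the scatter) and so adds a third substituted place-and-group pairing with a step beyond the scatter. The lower number on this ring is therefore not tied to nitro, since an entering group of 4 heavy atoms with 0 hydrogen-bond donors, 0 hydrogen-bond acceptors and no net charge also produces it, and among the compounds shown none with a substituent on this ring goes against the pattern. Nothing available here bears on the cause of this step.

Since each group appears at different places, the compounds shown do not separate the effect of the entering group from that of its place on the ring. As far as these compounds go, whether an amine or a carboxylic acid at the same place would also lower the number remains open, as does whether a longer chain on the ring would be accepted in the same way.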